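Shifting a Methyl on the Sulfonamide Aryl Ring

A few compounds are considered here, and "the series" means these few. Any claim that something is new, unique, unknown or untested is made for them only; others in the source may bear on it.

Measured so far in a functional assay on M21 cells (Homo sapiens) for antiproliferative activity, read by sulforhodamine B assay, with a stated time of 48 h; on this read-out higher numbers stand for weaker inhibition and lower numbers for stronger inhibition:
Compound 1 `Cc1ccccc1NS(=O)(=O)c1ccc(N2CCNC2=O)cc1` gives 150 nM.
Compound 3 `Cc1cc(C)cc(NS(=O)(=O)c2ccc(N3CCNC3=O)cc2)c1` gives 63 nM.
Compound 2 `CC(C)(C)c1ccc(NS(=O)(=O)c2ccc(N3CCNC3=O)cc2)cc1` reaches only a limit of the assay, > 1000 nM.

Among the two real numbers, compound 1 has the higher one; its nearest neighbour is compound 3, reached by a 2.4-fold lower number from compound 1 to compound 3 (0.38 log units; beyond the scatter). Compound 2 sits at the limit of > 1000 nM in this assay, at which 1 of the 3 values shown sits, so it gives no number to compare.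

Compound 4 `CCc1cccc(NS(=O)(=O)c2ccc(N3CCNC3=O)cc2)c1` has not yet been measured. Relative to compound 1 the change is 3-ethylphenyl in place of 2-methylphenyl on a sulfonamide nitrogen. Among the measured compounds shown here, the one step that bears on it is the move from compound 1 to compound 3, where substituents away from the attachment point gave a modest, beyond-scatter drop. A single 3-ethyl group is expected to act similarly, though perhaps less strongly, so a modest downward step is estimated: compound 4 is expected to give 85 nM, in a range of 30 nM to 250 nM, which means a 1.8-fold lower number from compound 1 to compound 4 (0.25 log units; within the scatter).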

Compound 4, half-maximal inhibitory concentration: 82 nM
Beside the measured number, compound 4's estimate is 1.0-fold (0.02 log units) above it, within the range that was stated.
By their numbers in this assay, from the lowest: compounds 3, 4 and 1 (each within the scatter of the next, the first and the last beyond it). At a limit, above all of these: compound 2.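

Going from 2-methylphenyl to 3-ethylphenyl on the sulfonamide nitrogen gives a 1.8-fold lower number from compound 1 to compound 4 (0.26 log units; within the scatter) and so cannot be told apart from no change. Set against 3,5-dimethylphenyl, the same group gives a 1.3-fold higher number from compound 3 to compound 4 (0.11 log units; within the scatter), so one ethyl group and two methyl groups cannot be told apart either. Compound 4 therefore falls within the scatter of both neighbours, even though those two differ from each other beyond it.

Still open, going by these compounds, is how a longer chain such as propyl, an amine or a carboxylic acid would behave on this aryl ring. Nothing measured here gives a reason for these numbers.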